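From 3-bromophenyl to pyridin-2-yl on the amide

This account rests on a few compounds, and the source may have more. Where it says the series, first, only, none or still open, it means among the compounds named here.

In a functional assay on MGC-803 cells (Homo sapiens) for inhibition, read by MTT assay, with a stated time of 72 h (on this read-out higher numbers stand for weaker inhibition and lower numbers for stronger inhibition), compound 3 `O=C(Nc1cccc(Br)c1)C1CCN(C/C=C/c2ccccc2)CC1` gives 9110 nM and compound 1 `CCc1ccc(NC(=O)C2CCN(C/C=C/c3ccccc3)CC2)cc1` gives 11600 nM so that the step reads a 1.3-fold lower number from compound 1 to compound 3 (0.10 log units; within the scatter) and leaves the two level. Compound 2 `COc1ccccc1NC(=O)C1CCN(C/C=C/c2ccccc2)CC1` stands apart at 71200 nM and the gap reads a 7.8-fold lower number from compound 2 to compound 3 (0.89 log units; beyond the scatter) for that pair. Compound 4 `O=C(Nc1ccccn1)C1CCN(C/C=C/c2ccccc2)CC1` has pyridin-2-yl in place of 3-bromophenyl on an amide-type nitrogen at the one place where the measured compounds differ. Going by the values given here, there, a 6.1-fold higher number from compound 1 to compound 2 (0.79 log units; beyond the scatter) shows that a swap can raise the number, yet no measured compound carries a hetero atom in this ring. A modest rise is therefore expected, and the estimated step is a 3.3-fold higher number from compound 3 to compound 4 (0.52 log units; beyond the scatter) in this reading. Compound 4 is estimated at 30000 nM with an expected range from 9000 nM to 90000 nM in this assay once measured.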

Compound 4, half-maximal inhibitory concentration: 45200 nM
For compound 4 the middle estimate is 1.5-fold (0.18 log units) below the measured one; low and high end bracket the measured number.
By their numbers in this assay, from the lowest: compounds 3 and 1 (each within the scatter of the next); then compounds 4 and 2 (each within the scatter of the next).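

Going by these compounds alone, compound 4 is the first compound here with a hetero atom in this ring, and in this assay pyridin-2-yl does not hold the level of the carbon-only rings of compound 3 (a 5.0-fold higher number from compound 3 to compound 4 (0.70 log units; beyond the scatter)) and compound 1 (a 3.9-fold higher number from compound 1 to compound 4 (0.59 log units; beyond the scatter)). It stays level with the 2-methoxyphenyl of compound 2 (a 1.6-fold lower number from compound 2 to compound 4 (0.20 log units; within the scatter)), so a carbon-only ring on the amide-type nitrogen does not by itself give the lower numbers. Nothing available explains these steps.

As far as these compounds go, whether a pyridin-3-yl or pyridin-4-yl group would read like compound 4 or like compound 3 remains open.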